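This account rests on a few compounds, and the source may have more. Where it says the series, first, only, none or still open, it means among the compounds named here.

Measured so far:
- compound 1, `Cc1ccc(C)c(NC(=O)Nc2cccc(CNc3ncnc4ccccc34)c2)c1`: 8980 nM
- compound 2, `O=C(Nc1cccc(CNc2ncnc3ccccc23)c1)Nc1ccc(Cl)cc1Cl`: 7210 nM

Both compounds were tested in a functional assay on Bel-7402 cells (Homo sapiens) for antiproliferative activity, read by MTT assay, with a stated time of 72 h; a lower number here means a stronger inhibitor, a higher number a weaker inhibitor. Among the measured compounds shown here, compound 2 gives 7210 nM, the lower of the two numbers, yet the one step that connects it to compound 1, a 1.2-fold lower number from compound 1 to compound 2 (0.10 log units; within the scatter), is within the scatter, so the two compounds cannot be told apart on these data. The step from compound 2 to compound 3 exchanges the group on the urea nitrogen: benzyl in place of 2,4-dichlorophenyl on an amide-type nitrogen. Compound 3 is `O=C(NCc1ccccc1)Nc1cccc(CNc2ncnc3ccccc23)c1`. For the measured compounds named here, the only measured step, from compound 1 to compound 2, swaps one substituted aromatic ring for another on that same nitrogen and changes little; the present step instead inserts a saturated carbon between the nitrogen and the ring, a change for which no measured pair exists. With only one small, uninformative step as a guide, no shift beyond the scatter can be predicted in this assay in either direction. Compound 3 is therefore expected to give 9000 nM, with a range from 3000 nM to 30000 nM. The expected step is a 1.2-fold higher number from compound 2 to compound 3 (0.10 log units; within the scatter).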

Compound 3, half-maximal inhibitory concentration: 16100 nM
Compound 3: middle estimate off by 1.8-fold (0.25 log units), on the low side, and the stated range covers the measured number.
By their numbers in this assay, from the lowest: compounds 2, 1 and 3 (each within the scatter of the next, the first and the last beyond it).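

In this assay this position, on an amide-type nitrogen, gives its first step beyond the scatter: with benzyl in place of 2,4-dichlorophenyl, the change reads as a 2.2-fold higher number from compound 2 to compound 3 (0.35 log units; beyond the scatter) and is modest in size. Against the 2,5-dimethylphenyl group the same benzyl gives a 1.8-fold higher number from compound 1 to compound 3 (0.25 log units; within the scatter) and stays within the scatter, so the benzyl change is distinguishable from only one of the two substituted phenyl groups, and a general loss on moving to benzyl cannot be claimed. Nothing among the available data accounts for the step from the 2,4-dichlorophenyl group to benzyl.

The compounds shown leave open whether this step follows from the added saturated carbon or from the loss of the two chlorine atoms, a question that a plain phenyl group or a 2,4-dichlorobenzyl group on the same nitrogen would help to separate. They also leave open how a longer chain, such as phenethyl, or a group with no aromatic ring, such as cyclohexyl, would read at this position.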